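Two pyrazolyl chalcones and a trimethoxy pattern

This account rests on a few compounds, and the source may have more. Where it says the series, first, only, none or still open, it means among the compounds named here.

In a functional assay on NCI-H226 cells (Homo sapiens) for cytotoxicity, read by sulforhodamine B assay, with a stated time of 48 h, tested at 0.01 uM (a higher number here means a weaker effect of the compound at the concentration tested, a lower number a stronger effect), compound 1 `COc1cc(-c2cc(/C=C/C(=O)c3ccc(N)cc3)[nH]n2)cc(OC)c1OC` gives 92% and compound 2 `COc1ccc(-c2cc(/C=C/C(=O)c3ccc(N)cc3)[nH]n2)cc1OC` gives 93%. The two differ by one change, (hydrogen in place of methoxy on an aromatic carbon), and the step of a number 1 percentage points higher from compound 1 to compound 2 (within the scatter) is within the scatter. Compound 3 `COc1cc(C(=O)/C=C/c2cc(-c3cc(OC)c(OC)c(OC)c3)n[nH]2)cc(OC)c1OC` gives 99% in this assay; its core differs from that of compound 1 in a way that is not broken down here. Compound 4 `COc1ccc(-c2cc(/C=C/C(=O)c3cc(OC)c(OC)c(OC)c3)[nH]n2)cc1OC` has not been measured. It differs from compound 3 by hydrogen in place of methoxy on an aromatic carbon, the same change that led from compound 1 to compound 2, at a place described in the same words. Resting on that earlier step, compound 4 is expected to move by no change at the digits printed from compound 3 to compound 4 (within the scatter) in this assay. Compound 4 is therefore estimated at 99%, between 91% and 105%.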

Compound 4, a percentage reported as activity, at one concentration (the size of the read-out at that concentration, not a potency): 93%
For compound 4 the middle estimate is 6 percentage points above the measured one; the range from low to high includes it.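

In this assay, hydrogen in place of methoxy on an aromatic carbon of the core of compound 3 gives a number 6 percentage points lower from compound 3 to compound 4 (within the scatter). Set beside the earlier step, the change reads alike on the two cores: the same change on two cores in this assay, a number 1 percentage points higher (within the scatter) from compound 1 to compound 2 and a number 6 percentage points lower (within the scatter) from compound 3 to compound 4, 7 percentage points apart, within the scatter of two such steps. This shows that the change carried from one core to the other without a step beyond the scatter, but it rests on two small steps at a single concentration and does not show that the cores would respond alike where a larger step appears.

Going by these compounds, what a hydroxyl group, a fluorine atom or an ethoxy group would do on that same aromatic carbon stays open. So does whether the change would read the same on a third core.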